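A few compounds are considered here, and "the series" means these few. Any claim that something is new, unique, unknown or untested is made for them only; others in the source may bear on it.

Measured in a functional assay on MDA-MB-231 cells (Homo sapiens) for antiproliferative activity, read by MTT assay; on this read-out lower numbers stand for stronger inhibition and higher numbers for weaker inhibition:

Compound 1 `CCCCC/C=C\C/C=C\CCCCCCCc1cc(=O)c2c(O)c(C)c(OCOC)c(C)c2o1`: 16100 nM
Compound 2 `CCCCCCCCCCCCCCCc1cc(=O)c2c(O)c(C)c(OCOC)cc2o1`: > 87000 nM (a limit)

Compound 2 stands only at a limit, (the limit of > 87000 nM in this assay, at which 1 of the 2 values shown sits). Compound 3 `CCCCC/C=C\C/C=C\CCCCCCCc1cc(=O)c2c(O)c(C)c(OCOC)cc2o1` keeps the core of compound 2 and changes the chain: deca-1,4-dien-1-yl in place of octyl on a saturated chain carbon, seven bonds along the chain from an aromatic carbon. In words, deca-1,4-dien-1-yl takes the place of octyl on a saturated chain carbon, seven bonds along the chain from an aromatic carbon. For the measured compounds named here, no step between measured compounds is available in this assay, so the expectation rests on two values alone. Compound 1, which carries the same unsaturated chain, gives 16100 nM, and this points towards stronger inhibition for compound 3. The estimated at least 2.1-fold lower number from compound 2 to compound 3 (0.33 log units; beyond the scatter) is therefore a moderate one in that direction, and compound 3 may still reach the limit. For compound 3 the expected value is 40000 nM, with an estimated range from 14000 nM to 100000 nM.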

Compound 3, half-maximal inhibitory concentration: > 87000 nM
Compound 3 ended at the assay's limit; the forecaster's own chance of this, stated with the estimate: 30%; middle value at least 2.1-fold (0.33 log units) from the limit.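

In this assay compound 3 gives > 87000 nM, which is a limit of the assay and not a number. The change from octyl to deca-1,4-dien-1-yl on the chain cannot be read, because compound 2 and compound 3 stand at the same limit: the limit of > 87000 nM in this assay, at which 2 of the 3 values shown sit.

What the result adds concerns the aromatic carbon: with the deca-1,4-dien-1-yl chain kept, hydrogen in place of methyl gives an at least 5.4-fold higher number from compound 1 to compound 3 (0.73 log units; beyond the scatter), so the measurable inhibition by compound 1 is lost with that methyl, which the earlier pair could not show.

On these data alone, whether the chain matters when that methyl is present remains open. So does whether an ethyl group, a chlorine atom or a methoxy group on that aromatic carbon would keep the inhibition seen with methyl.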